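A few compounds are considered here, and "the series" means these few. Any claim that something is new, unique, unknown or untested is made for them only; others in the source may bear on it.

In a toxicity assay on CCRF-CEM cells (Homo sapiens) for cytotoxicity; a higher number here means that more compound is tolerated, a lower number that less compound is tolerated:
- Compound 1 `Oc1cccc2c1nc(-c1c(F)cccc1F)n2Cc1c(F)cccc1F`: > 100 uM (a limit of the assay, not a number)
- Compound 2 `Fc1cccc(F)c1Cn1c(-c2c(F)cccc2F)nc2c(Br)cccc21`: 24.5 uM
- Compound 3 `CNc1cccc2c1nc(-c1c(F)cccc1F)n2Cc1c(F)cccc1F`: 27.2 uM

The two real numbers are level, as a 1.1-fold higher number from compound 2 to compound 3 (0.05 log units; within the scatter) lies within the scatter. So compound 3 stands together with compound 2, while compound 1 offers only its limit.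

Compound 4 `N#Cc1cccc2c1nc(-c1c(F)cccc1F)n2Cc1c(F)cccc1F` carries cyano in place of methylamino on an aromatic carbon. Bromo and methylamino gave matching numbers here. Compound 1 goes against this, with an at least 4.0-fold lower number from compound 1 to compound 2 (0.61 log units; beyond the scatter) and an at least 3.6-fold lower number from compound 1 to compound 3 (0.56 log units; beyond the scatter), both beyond the scatter. Cyano is untested, so hydroxy's larger gap keeps the upper range wide. The expected result is a 1.1-fold higher number from compound 3 to compound 4 (0.04 log units; within the scatter), no step beyond the scatter. The estimated value for compound 4 is 30 uM, ranging from 13 uM to 80 uM.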

Compound 4, half-maximal toxic concentration: 26.7 uM
Compound 4: the middle estimate sits 1.1-fold (0.05 log units) above what was measured; the measured number falls inside the stated range.
By their numbers in this assay, from the lowest: compounds 2, 4 and 3 (each within the scatter of the next). At a limit, above all of these: compound 1.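

In this assay, cyano, with no hydrogen-bond donor, reads level with methylamino, which has one, at this position on the aromatic ring (a 1.0-fold lower number from compound 3 to compound 4 (0.01 log units; within the scatter)). Cyano also matches bromo (a 1.1-fold higher number from compound 2 to compound 4 (0.04 log units; within the scatter)), so three different groups now sit level here, and only the hydroxy of compound 1 goes against this (an at least 3.7-fold lower number from compound 1 to compound 4 (0.57 log units; beyond the scatter)). The value of compound 1 is a limit of the assay, not a number: the limit of > 100 uM in this assay, at which 1 of the 4 values shown sits.

From the compounds shown here alone, whether a carboxylic acid or a longer chain at this position would also sit level with these three stays open. Going by these compounds, how far compound 1 truly lies from them stays open too.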